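This account rests on a few compounds, and the source may have more. Where it says the series, first, only, none or still open, it means among the compounds named here.

Measured compounds:
Compound 1 `Nc1cc(N)c2nc(-c3ccccc3)c(NCc3ccc(F)cc3)nc2c1`: 1510 nM
Compound 2 `COc1ccc(CNc2nc3cc(N)cc(N)c3nc2-c2ccccc2)cc1`: 21900 nM

In a functional assay on DU-145 cells (Homo sapiens) for inhibition, read by sulforhodamine B assay, with a stated time of 48 h (a lower number here means a stronger inhibitor of growth, a higher number a weaker inhibitor of growth), compound 1 gives 1510 nM, the lowest of the two numbers measured; its nearest neighbour is compound 2, which is separated from it by a 15-fold higher number from compound 1 to compound 2 (1.16 log units; beyond the scatter). Compound 3 `Nc1cc(N)c2nc(-c3ccccc3)c(Oc3ccc(F)cc3)nc2c1` is not yet measured. It differs from compound 1 in one place: 4-fluorophenoxy in place of (4-fluorobenzyl)amino on an aromatic carbon. Within the data shown here, the only measured step, from compound 1 to compound 2, changes the group at the far end of the benzyl arm and so does not bear on the linking part between the core and the ring; no measured pair shows what exchanging an amine linker for an ether linker does here. The change does remove the single hydrogen-bond donor of the leaving group. The step is therefore expected to be modest and toward a higher number, a 2.6-fold higher number from compound 1 to compound 3 (0.42 log units; beyond the scatter), and compound 3 is estimated at 4000 nM in this assay, within a range of 1200 nM to 15000 nM.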

Compound 3, concentration for 50% growth inhibition: 460 nM
For compound 3 the middle estimate is 8.7-fold (0.94 log units) above the measured one, and the stated range ends above it.
By their numbers in this assay, from the lowest: compound 3; then compound 1; then compound 2.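

In this assay, the change to 4-fluorophenoxy from (4-fluorobenzyl)amino gives a 3.3-fold lower number from compound 1 to compound 3 (0.52 log units; beyond the scatter), so this aromatic carbon next to the ring nitrogen accepts a different link between the shared core and the fluorinated ring. The entering group carries no hydrogen-bond donor, which shows that a donor in this link is not required for growth inhibition at this level. Nothing given here explains why the number falls.

The swap changes both the linking atom and the length of the arm, so the compounds shown cannot separate those two effects; a 4-fluorobenzyloxy group or a 4-fluoroanilino group would pull them apart. Going by these compounds, it also remains open whether a methoxy group on the phenoxy ring would raise the number as it does on the benzyl arm.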